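Working notes: from compound 3 to compound 4

The source may report more compounds than this note shows. Statements on the series, on what has been measured and on what is new or still open speak of the compounds shown alone.

Measured in a functional assay on B16 cells (Mus musculus) for inhibition, with a stated time of 72 h; a lower number here means a stronger inhibitor, a higher number a weaker inhibitor:
- compound 1 `S=C1NCCN1Cc1ccc(Cl)cc1` gives 4300 nM
- compound 2 `COc1ccc(CN2CCNC2=S)cc1` gives > 10000 nM, which is a limit
- compound 3 `Cc1ccc(CN2CCCNC2=S)cc1` gives 5100 nM

Among the two numerical values, compound 3 (5100 nM) and compound 1 (4300 nM) lie within the scatter of each other, so no order can be drawn between them. Compound 2 reports only a limit (> 10000 nM).

Compound 4 `CCc1ccc(CN2CCCNC2=S)cc1` keeps the core of compound 3 and changes one place: methyl in place of hydrogen on a saturated chain carbon bound to an aromatic carbon. In words, this is methyl in place of hydrogen on a saturated chain carbon bound to an aromatic carbon, so methyl becomes ethyl.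

Going by the values given here, only one measured step is available, an at least 2.3-fold higher number from compound 1 to compound 2 (0.36 log units; beyond the scatter), which goes beyond the scatter. It is methoxy in place of chloro on an aromatic carbon, it ends at a limit, and it sits on the core of compound 1. Among the compounds with values here, it therefore bears only loosely on this change, and no measured step tests methyl to ethyl directly. The nearest anchor is compound 3 at 5100 nM, so no shift beyond the scatter is expected in this assay and no direction is favoured. The expected size is a 1.0-fold lower number from compound 3 to compound 4 (0.01 log units; within the scatter). For compound 4 the estimated value is 5000 nM, with an expected range from 2300 nM to 10000 nM.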

Compound 4, half-maximal inhibitory concentration: 1300 nM
The estimate for compound 4 lay 3.8-fold (0.59 log units) above the measured number; measured number outside the range, below it.
By their numbers in this assay, from the lowest: compound 4; then compounds 1 and 3 (each within the scatter of the next). At a limit, above all of these: compound 2.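

In this assay, methyl in place of hydrogen on a saturated chain carbon bound to an aromatic carbon, which turns methyl into ethyl, gives a 3.9-fold lower number from compound 3 to compound 4 (0.59 log units; beyond the scatter), and this is the only step shown at this place. The earlier compounds shown here held no comparison at this place, so they could not show that it responds at all; this pair shows that 1 added carbon is enough to move the number beyond the scatter, towards stronger inhibition, on the core of compound 3. Nothing on hand bears on the reason for this step.

From the compounds shown here alone, this is a single pair, so it remains open whether a longer chain such as propyl or butyl, or a branched group such as isopropyl, would lower the number further, hold it or reverse it, and how a polar end group such as an amine or a carboxylic acid on that chain would read. Going by these compounds, it also remains open whether methyl to ethyl gives a step of similar size on the core of compound 1.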